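This account rests on a few compounds, and the source may have more. Where it says the series, first, only, none or still open, it means among the compounds named here.

Of the compounds shown here, two with the same core have been measured so far. Compound 1, `Nc1nc(O)c2c(n1)n(C1OC(CO)[C@@H](O)[C@H]1O)c(=O)n2Cc1ccc(Cl)cc1`, in a functional assay on the whole organism (B cells) with Mus musculus as the target (a lower number here means a smaller maximal response, a higher number a larger maximal response), gives 15%. Compound 2, `C=CCn1c(=O)n(C2OC(CO[Si](C)(C)C(C)(C)C)[C@@H](O)[C@H]2O)c2nc(N)nc(O)c21`, in this assay gives 5%. Among the compounds with values here, compound 1 thus stands alongside compound 2, the only other measured compound, and the gap between the two numbers falls within the usual scatter of repeated measurements, so no ranking between them can be claimed; both reach only a small maximal response.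

Compound 3, `CN(C)CCCn1c(=O)n(C2OC(CO)[C@@H](O)[C@H]2O)c2nc(N)nc(O)c21`, has not yet been measured. Compared with compound 1 it carries a different group on the chain attached to the core: 2-(dimethylamino)ethyl in place of 4-chlorophenyl on a saturated chain carbon bound to an aromatic nitrogen.

Within the data shown here, no pair of measured compounds shows what a change of this kind does in this assay, so nothing measured points in one direction or the other. The expectation is therefore that the step of a number 3 percentage points lower from compound 1 to compound 3 (within the scatter) is small and stays within the scatter, because compound 1 gives 15% and compound 2 gives a nearby value, both of them low. Compound 3 is estimated to give 12%, with a likely range from 0% to 30%.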

Compound 3, largest response reached (reported as maximal response), in percent of the reference or control that the assay uses: 83%
The estimate for compound 3 lay 71 percentage points below the measured number; the measured number lies above the stated range.
By their numbers in this assay, from the lowest: compounds 2 and 1 (each within the scatter of the next); then compound 3.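

In this assay, within the data shown here, exchanging the 4-chlorobenzyl group of the shared core for 3-(dimethylamino)propyl gives a number 68 percentage points higher from compound 1 to compound 3 (beyond the scatter), the first step that clearly exceeds the scatter. This position is therefore far from indifferent: what sits on the chain attached to the core can decide whether the maximal response stays small or becomes large, something the two earlier numbers, close together and both low, could not reveal. No measurement at hand gives a reason for this step.

The single change removes the 4-chlorophenyl group and brings in the 2-(dimethylamino)ethyl group together, so the compounds shown leave open which of the two matters more, a question that a plain propyl chain at this position could help to separate. Also open, from the compounds shown here alone, is how this assay would respond to a longer chain ending in the same dimethylamino group, or to a primary amine or a pyrrolidine at the end of the chain.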